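This account rests on a few compounds, and the source may have more. Where it says the series, first, only, none or still open, it means among the compounds named here.

Compound 3 `Nc1nc(NCc2ccccc2F)nc(-c2c(F)cccc2CO)n1` stands highest of the three numbers in a functional assay on cells for positive allosteric modulation of G-protein coupled receptor 68 (Homo sapiens), read by a luciferase reporter and cAMP accumulation, with a stated time of 30 min, at pH 6.8 and pH 8.3, in the presence of a further agent that is not named here; on this read-out lower numbers stand for lower potency and higher numbers for higher potency (the scale is a negative logarithm): compound 3 gives 4.22, compound 2 `Nc1nc(NCc2ccc(F)cc2)nc(-c2ccccc2CO)n1` gives 3.97, within the scatter of that, and compound 1 `Nc1nc(NCc2ccccc2)nc(-c2c(F)cccc2CO)n1` gives 3.69, beyond the scatter. The step to compound 4 `Nc1nc(NCc2ccc(F)cc2)nc(-c2c(F)cccc2CO)n1` is 4-fluorophenyl in place of 2-fluorophenyl on a saturated chain carbon bound to a nitrogen on an aromatic ring. For the measured compounds named here, no measured step covers this swap directly. Going by the values given here, the one step touching the same carbon, a number 0.53 log units higher from compound 1 to compound 3 (beyond the scatter), adds the fluoro rather than moving it. Compound 2 shares the 4-fluorobenzyl of compound 4 but lacks the second fluoro of compound 3, and its value sits within the scatter of compound 3. The expected step is therefore a number 0.22 log units lower from compound 3 to compound 4 (within the scatter), within the scatter. Compound 4 is estimated at 4, with a range of 3.6 to 4.4.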

Compound 4, negative logarithm of the antagonist equilibrium constant: 4.45
The estimate for compound 4 lay 0.45 log units below the measured number; the measured number lies above the stated range.
By their numbers in this assay, from the lowest: compounds 1, 2, 3 and 4 (each within the scatter of the next, the first and the last beyond it).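

In this assay, 4-fluorophenyl in place of 2-fluorophenyl gives a number 0.23 log units higher from compound 3 to compound 4 (within the scatter) and does not separate the two placements of the fluoro on the benzyl group. Fluoro in place of hydrogen gives a number 0.76 log units higher from compound 1 to compound 4 (beyond the scatter) and a number 0.48 log units higher from compound 2 to compound 4 (beyond the scatter), so the gain from a fluoro now holds for both placements on the benzyl group. The size of that step recurs: the same change on two cores in this assay, a number 0.53 log units higher (beyond the scatter) from compound 1 to compound 3 and a number 0.48 log units higher (beyond the scatter) from compound 2 to compound 4, 0.05 log units apart, within the scatter of two such steps.

Open, on these data alone, is whether a chloro, a methoxy or a carboxylic acid in place of the fluoro, or a longer chain in place of the benzyl link, would hold these numbers.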